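The source may hold more compounds than are shown below. What is called first, only, known or untested is meant among the compounds shown, and "the series" means these compounds.

Measured so far in an in vitro functional assay on 1321-N1 cells for antagonist activity at transient receptor potential cation channel subfamily V member 1 (Homo sapiens), read by FLIPR and calcium flux; on this read-out lower numbers stand for stronger inhibition and higher numbers for weaker inhibition:
Compound 1, `CC(C)(C)c1ccc(NC(=O)C2=CCN(c3ccccn3)CC2)cc1`: 27 nM
Compound 2, `CC(C)(C)c1ccc(NC(=O)C2=CCN(c3ncccn3)CC2)cc1`: 10 nM

Among the measured compounds shown here, of these two numbers, compound 2 has the lower one; its only neighbour is compound 1, from which it is reached by a 2.7-fold lower number from compound 1 to compound 2 (0.43 log units; beyond the scatter). Compound 3, `CC(C)(C)c1ccc(NC(=O)C2=CCN(c3ccccc3F)CC2)cc1`, has not yet been measured. It differs from compound 2 in one place: 2-fluorophenyl in place of pyrimidin-2-yl on an amine nitrogen in a ring. For the measured compounds named here, the single measured step, a 2.7-fold lower number from compound 1 to compound 2 (0.43 log units; beyond the scatter), also exchanged the ring on that same ring nitrogen, swapping one aromatic ring with hetero atoms for another with one more nitrogen and one more hydrogen-bond acceptor, and the number fell. The change to compound 3 runs the other way, removing both hydrogen-bond acceptors and bringing in a carbon-only ring with a fluorine. Going by the values given here, no measured step covers such a ring, so the expectation rests on the direction of that one step. The step from compound 2 to compound 3 in this assay is expected to be a 4.0-fold higher number from compound 2 to compound 3 (0.60 log units; beyond the scatter), a rise of modest size. Compound 3 is estimated at 40 nM, within a range from 12 nM to 130 nM.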

Compound 3, half-maximal inhibitory concentration: 265 nM
Compound 3: middle estimate off by 6.6-fold (0.82 log units), on the low side, and the stated range ends below it.
By their numbers in this assay, from the lowest: compound 2; then compound 1; then compound 3.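

In this assay the choice of ring on the amine nitrogen proves able to move the number much further than the first step showed, with a 27-fold higher number from compound 2 to compound 3 (1.42 log units; beyond the scatter) and a 9.8-fold higher number from compound 1 to compound 3 (0.99 log units; beyond the scatter) as well, so both rings containing nitrogen give stronger inhibition here than 2-fluorophenyl. This exchange removes the ring nitrogens and adds a fluorine at once, and the compounds shown cannot separate those two changes. No measured evidence here explains the size of the rise.

An unsubstituted phenyl ring, or one carrying chlorine or methoxy in place of fluorine, would help show whether the fluorine or the carbon-only ring accounts for the loss. Also open, going by these compounds, is whether a non-aromatic group on this nitrogen, such as an acetyl group, could keep inhibition at all.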